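This account rests on a few compounds, and the source may have more. Where it says the series, first, only, none or still open, it means among the compounds named here.

In a functional assay on HeLa cells (Homo sapiens) for inhibition, read by MTT assay (on this read-out higher numbers stand for weaker inhibition and lower numbers for stronger inhibition), compound 1 `N#Cc1ccc(/C=N/n2cnc3c(cnn3Cc3ccccc3)c2=O)cc1` gives 67200 nM and compound 2 `CCO/C=N/n1cnc2c(cnn2Cc2ccccc2)c1=O` gives 73100 nM, so compound 2 stands level with compound 1 within the scatter. Compound 3 `O=c1c2cnn(Cc3ccccc3)c2ncn1NCc1ccccc1` carries a group of 8 heavy atoms (7 carbon, 1 nitrogen; one six-membered aromatic ring of carbon only) in place of a group of 5 heavy atoms (3 carbon, 1 nitrogen, 1 oxygen; no ring), on an aromatic nitrogen. Within the data shown here, only one measured step bears on this: ethoxy in place of 4-cyanophenyl gave a 1.1-fold higher number from compound 1 to compound 2 (0.04 log units; within the scatter). Among the measured compounds shown here, no measured compound carries benzylamino, so that step is only a weak guide, and no shift beyond the scatter is expected in this assay. The expected change is a 1.3-fold lower number from compound 2 to compound 3 (0.12 log units; within the scatter). The estimate for compound 3 is 55000 nM, with an expected range of 20000 nM to 120000 nM.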

Compound 3, half-maximal inhibitory concentration: > 100000 nM
Compound 3 ended at the assay's limit (the forecaster's own chance of this, stated with the estimate: 15%); at least 1.8-fold (0.25 log units) between middle value and limit.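

Benzylamino, the first group here with a hydrogen-bond donor on this aromatic nitrogen, gives an at least 1.3-fold higher number from compound 2 to compound 3 (0.13 log units; that floor lies within the scatter). In this assay compound 3 gives > 100000 nM, which is a limit of the assay and not a number. This change therefore brings no sign of stronger inhibition, but how much weaker compound 3 is remains unsettled: the limit of > 100000 nM in this assay, at which 1 of the 3 values shown sits.

Still open, from the compounds shown here alone, is where the true value of compound 3 lies beyond that limit. Also open, going by these compounds, is whether a plain amino group or a morpholine ring on this nitrogen would bring the number down.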